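Replacing Furan-3-yl with 2-Chlorophenyl on the Shared Core

The source may hold more compounds than are shown below. What is called first, only, known or untested is meant among the compounds shown, and "the series" means these compounds.

In a functional assay on Z-138 cells (Homo sapiens) for antiproliferative activity, with a stated time of 72 h (a lower number here means a stronger inhibitor, a higher number a weaker inhibitor), compound 1 (`CCCC#Cc1cc([C@@H]2O[C@H](CO)[C@@H](O)[C@H]2O)n2ncnc(N)c12`) gives 20 nM, while compound 2 (`Nc1ncnn2c([C@@H]3O[C@H](CO)[C@@H](O)[C@H]3O)cc(-c3ccoc3)c12`) gives 300 nM, the higher of the two numbers. Compound 3 (`Nc1ncnn2c([C@@H]3O[C@H](CO)[C@@H](O)[C@H]3O)cc(-c3ccccc3Cl)c12`) carries 2-chlorophenyl in place of furan-3-yl on an aromatic carbon. For the measured compounds named here, one measured step bears on this change, at the same aromatic carbon: a 15-fold higher number from compound 1 to compound 2 (1.18 log units; beyond the scatter), a large step. Going by the values given here, a further moderate rise in this assay is therefore expected, though the data hold no direct precedent for an aryl group with chlorine. The expected step is a 3.0-fold higher number from compound 2 to compound 3 (0.48 log units; beyond the scatter). Compound 3 is estimated at 900 nM, with an expected range of 200 nM to 4000 nM.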

Compound 3, half-maximal inhibitory concentration: 76100 nM
For compound 3 the middle estimate is 85-fold (1.93 log units) below the measured one; measured number above the stated range.
By their numbers in this assay, from the lowest: compound 1; then compound 2; then compound 3.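

At this aromatic carbon, 2-chlorophenyl costs far more than furan-3-yl did: this assay shows a 250-fold higher number from compound 2 to compound 3 (2.40 log units; beyond the scatter), and against the pent-1-yn-1-yl group it shows a 3800-fold higher number from compound 1 to compound 3 (3.58 log units; beyond the scatter). Two aromatic groups at the same place can therefore give widely separated numbers, so an aromatic ring alone does not set the value here. Nothing available explains this gap. The compounds shown leave open whether the chlorine or the six-membered ring accounts for the rise, which a plain phenyl group would separate. From the compounds shown here alone, how an amine on this carbon would read also remains open.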